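The source may report more compounds than this note shows. Statements on the series, on what has been measured and on what is new or still open speak of the compounds shown alone.

Measured so far in a functional assay on HeLa cells (Homo sapiens) for antiproliferative activity, with a stated time of 24 h; a higher number here means a weaker inhibitor, a lower number a stronger inhibitor: compound 1, `NC(=O)c1c(NC(=O)c2ccccc2Cl)sc2c1CCN(Cc1cc(Cl)cc(Cl)c1)C2`, gives 19600 nM. Compound 2, `NC(=O)c1c(NC(=O)c2ccccc2Cl)sc2c1CCN(C(=S)Nc1ccccc1F)C2`, gives 28700 nM. Compound 3, `COc1ccccc1NC(=S)N1CCc2c(sc(NC(=O)c3ccccc3Cl)c2C(N)=O)C1`, gives > 50000 nM, which is a limit of this assay rather than a number.

Compound 3 thus sits at the limit of > 50000 nM in this assay, at which 1 of the 3 values shown sits. The steps of an at least 2.5-fold higher number from compound 1 to compound 3 (0.40 log units; beyond the scatter) and an at least 1.7-fold higher number from compound 2 to compound 3 (0.24 log units; that floor lies within the scatter) both end at that limit, while a 1.5-fold higher number from compound 1 to compound 2 (0.17 log units; within the scatter) stays within the scatter. Compound 4, `COc1ccc(NC(=S)N2CCc3c(sc(NC(=O)c4ccccc4Cl)c3C(N)=O)C2)cc1`, differs from compound 3 only in 4-methoxyphenyl in place of 2-methoxyphenyl on an amide-type nitrogen. Within the data shown here, no measured step moves a methoxy group from one place on that ring to another, so nothing measured bears on this change directly. The expectation is therefore a step that the limit leaves unreadable from compound 3 to compound 4, meaning nothing beyond the scatter. Compound 4 is estimated at 60000 nM, ranging from 20000 nM to 200000 nM, and a limit is again likely.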

Compound 4, half-maximal inhibitory concentration: 36400 nM
For compound 4 the middle estimate is 1.6-fold (0.22 log units) above the measured one, and the stated range covers the measured number.
By their numbers in this assay, from the lowest: compounds 1, 2 and 4 (each within the scatter of the next). At a limit, above all of these: compound 3.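

Compound 3 stands at a limit of the assay: the limit of > 50000 nM in this assay, at which 1 of the 4 values shown sits.

With 4-methoxyphenyl on the amide-type nitrogen, the assay gives a readable number, and an at least 1.3-fold lower number from compound 3 to compound 4 (0.13 log units; that floor lies within the scatter), so moving the methoxy group is not shown to matter. Two further steps, a 1.3-fold higher number from compound 2 to compound 4 (0.10 log units; within the scatter) and a 1.9-fold higher number from compound 1 to compound 4 (0.27 log units; within the scatter), also stay within the scatter, leaving these three values indistinguishable.

Going by these compounds, whether any change on this ring can give a step beyond the scatter remains open. An amine or a carboxylic acid in place of the methoxy group could test this.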